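This account rests on a few compounds, and the source may have more. Where it says the series, first, only, none or still open, it means among the compounds named here.

Measured so far:
compound 1, `O=C(CN1CCN(c2ccccn2)CC1)Nc1cncnc1`: > 100000 nM
compound 2, `O=C(CN1CCN(c2ccc(Cl)cn2)CC1)Nc1cncnc1`: > 100000 nM

In a functional assay on cells for antagonist activity at D(4) dopamine receptor (Homo sapiens), read by TR-FRET and cAMP accumulation, with a stated time of 30 min (a lower number here means a stronger inhibitor, a higher number a weaker inhibitor), compound 1 gives > 100000 nM, which is a limit of the assay and not a number. Compound 2 likewise gives > 100000 nM in this assay, again a limit. Going by the values given here, the one measured step, a step that the two limits leave unreadable from compound 1 to compound 2, cannot be read because both values sit at the limit of > 100000 nM in this assay, at which 2 of the 2 values shown sit. Compound 1 therefore stands nowhere definite on the numbers shown; only a limit is known for it.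

Compound 3, `Cc1cccc(NC(=O)CN2CCN(c3ccccn3)CC2)c1`, differs from compound 1 by 3-methylphenyl in place of pyrimidin-5-yl on an amide-type nitrogen. Among the compounds with values here, no measured step touches this kind of change; the only step known concerns a chloro and is itself unreadable. The measured compounds give no reason to expect compound 3 to leave the limit, and no size or direction of step can be read from them, so the estimate rests on that silence. Compound 3 is expected at 80000 nM, within 3000 nM to 300000 nM. This corresponds to an expected step of an at least 1.2-fold lower number from compound 1 to compound 3 (0.09 log units; that floor lies within the scatter).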

Compound 3, half-maximal inhibitory concentration: 82.7 nM
The estimate for compound 3 lay 970-fold (2.99 log units) above the measured number; measured number outside the range, below it.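

Going by these compounds alone, the group on the amide-type nitrogen is the first place where a change gives a readable number. In this assay, putting 3-methylphenyl in place of pyrimidin-5-yl gives an at least 1200-fold lower number from compound 1 to compound 3 (3.08 log units; beyond the scatter), whereas the chloro step from compound 1 to compound 2 cannot be read. The step size is only a floor, because compound 1 gives a limit of the assay and not a number: the limit of > 100000 nM in this assay, at which 2 of the 3 values shown sit.

The change swaps a ring with hetero atoms for a ring of carbon only and also brings in a methyl, and the compounds shown cannot separate these two parts; a plain phenyl, or an amine in place of the methyl, would bear on this. They also leave open what a chloro does in compound 3, where a number can now be read.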